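The compounds below may be only part of what the source reports. "The series", "measured", "known", "first", "only" and "open" are said of these compounds alone.

Measured in a functional assay on HepG2 cells (Homo sapiens) for inhibition, read by MTT assay, with a stated time of 72 h; a lower number here means a stronger inhibitor, a higher number a weaker inhibitor:
- Compound 1 `Cc1ccc(-c2cc(C(=O)N3CCC4(CC3)CC(=O)c3nn(C(C)(C)C)cc3O4)c3ccccc3n2)cc1`: 1440 nM
- Compound 2 `CC(C)(C)n1cc2c(n1)C(=O)CC1(CCN(C(=O)c3cc(N4CCNCC4)nc4ccccc34)CC1)O2`: 8570 nM
- Compound 3 `CC(C)(C)n1cc2c(n1)C(=O)CC1(CCN(C(=O)c3cc(Cl)nc4ccccc34)CC1)O2`: 4720 nM

Compound 3 is the starting point here, with a value of 4720 nM. It cannot be told apart from its piperazin-1-yl partner, as a 1.8-fold lower number from compound 2 to compound 3 (0.26 log units; within the scatter) shows. Its number does stand clear of the 4-methylphenyl compound, as a 3.3-fold higher number from compound 1 to compound 3 (0.52 log units; beyond the scatter) shows.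

Compound 4 `CC(C)Oc1cc(C(=O)N2CCC3(CC2)CC(=O)c2nn(C(C)(C)C)cc2O3)c2ccccc2n1` has not yet been measured. It carries isopropoxy in place of chloro on an aromatic carbon, next to the ring nitrogen: isopropoxy in place of chloro on an aromatic carbon. The measured steps all involve this same carbon, and the largest is a 6.0-fold higher number from compound 1 to compound 2 (0.77 log units; beyond the scatter), which is still modest. Among the measured compounds shown here, no measured compound has isopropoxy, so these steps offer only a rough guide to size. In this assay, the change is therefore expected to be small, with no clear shift in either direction. The estimated step is a 1.2-fold lower number from compound 3 to compound 4 (0.09 log units; within the scatter). For compound 4 the expected value is 3800 nM, with an estimated range from 1500 nM to 9500 nM.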

Compound 4, half-maximal inhibitory concentration: 3150 nM
Compound 4: the middle estimate sits 1.2-fold (0.08 log units) above what was measured; low and high end bracket the measured number.
By their numbers in this assay, from the lowest: compound 1; then compounds 4, 3 and 2 (each within the scatter of the next, the first and the last beyond it).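

In this assay, isopropoxy in place of chloro on this aromatic carbon, next to the ring nitrogen, gives a 1.5-fold lower number from compound 3 to compound 4 (0.18 log units; within the scatter) and so cannot be told apart from chloro, even with its larger count of heavy atoms. Unlike chloro, however, isopropoxy stands clear of piperazin-1-yl, with a 2.7-fold lower number from compound 2 to compound 4 (0.43 log units; beyond the scatter) as the modest step, and it also stands clear of 4-methylphenyl, with a 2.2-fold higher number from compound 1 to compound 4 (0.34 log units; beyond the scatter) as the step, which places it between those two groups. No measured data here explain these differences.

Going by these compounds, what a methoxy group, a longer alkoxy chain or an open-chain amine such as dimethylamino would give on this carbon stays open, as does whether any group here could give a lower number than compound 1 at 1440 nM in this series. Changes elsewhere on the shared core also remain unexplored in these compounds.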